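The compounds below may be only part of what the source reports. "The series", "measured", "known", "first", "only" and "open" are said of these compounds alone.

Measured in a functional assay on the whole organism for positive allosteric modulation, with Mus musculus as the target; a higher number here means that more compound is needed for the effect, a lower number that less compound is needed:
- compound 1 `CCC(=O)N(c1ccc(OC)cc1)C1CCCC1N(C)C`: 30 mg/kg; 30 mg/kg (2 entries)
- compound 2 `CCC(=O)N(c1cccc(C)c1)C1CCCC1N(C)C`: 3 mg/kg; 3 mg/kg (2 entries)
- compound 3 `CCC(=O)N(c1cccc(OC)c1)C1CCCC1N(C)C`: 0.8 mg/kg

Of the numbers shown, compound 3 has the lowest, at 0.8 mg/kg. Two further entries give no single number, so its standing rests on this one value.

The next compound to be measured is compound 4 `CCC(=O)N(c1ccc(OC)c(OC)c1)C1CCCC1N(C)C`. It differs from compound 3 by methoxy in place of hydrogen on an aromatic carbon, ortho to a methoxy group and para to a large group.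

Among the compounds with values here, no step between measured compounds that differ in one place is available, so the expectation rests on the values alone. Compound 1 also carries a methoxy group para to a large group and gives 30 mg/kg; 30 mg/kg (2 entries), whereas compound 3 gives 0.8 mg/kg. Neither measured compound carries two methoxy groups, so this comparison is only indirect.

A rise in the required dose beyond the usual scatter is expected, with the value staying short of that of compound 1. The estimated change is a 7.5-fold higher number from compound 3 to compound 4 (0.88 log units; beyond the scatter). For compound 4 the expected value is 6 mg/kg, with an estimated range of 1.5 mg/kg to 25 mg/kg.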

Compound 4, dose for half-maximal effect: 9 mg/kg
Beside the measured number, compound 4's estimate is 1.5-fold (0.18 log units) below it; the range from low to high includes it.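

In this assay, the series now has its first step between compounds that differ in one place, and it is large: an 11-fold higher number from compound 3 to compound 4 (1.05 log units; beyond the scatter). Adding methoxy on this aromatic carbon, ortho to a methoxy group and para to a large group, therefore raises the required dose, and the methoxy group already present in compound 3 does not prevent that rise. Both compounds with a methoxy group para to a large group, compound 1 at 30 mg/kg; 30 mg/kg (2 entries) and compound 4 at 9 mg/kg, now show higher numbers than compound 3, although no data in hand give a reason for the rise.

The compounds shown do not tell whether this rise is particular to methoxy or would also follow from fluorine, a hydroxyl group or an amine on the same aromatic carbon. They also leave open whether a longer ether such as ethoxy in place of the methoxy group of compound 3 would keep the low dose requirement, and whether the change would read the same on the methyl-bearing ring of compound 2.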